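Bombesin receptor subtype-3 agonists: swapping the imidazole substituent

The source may report more compounds than this note shows. Statements on the series, on what has been measured and on what is new or still open speak of the compounds shown alone.

Compound 1, `N#Cc1cccc(Cc2cnc(CCc3ccc(-c4ccccc4C(=O)O)cc3)[nH]2)c1`: 20 nM
Compound 2, `CCCCc1cnc(C(Cc2ccc(-c3ccccc3C(=O)O)cc2)C(C)C)[nH]1`: 2240 nM
Compound 3, `CCCCc1cnc(Cc2ccc(-c3ccccc3C(=O)O)cc2)[nH]1`: > 10000 nM

In an in vitro functional assay on cells for agonist activity at Bombesin receptor subtype-3 (Mus musculus), read by luminescence and calcium flux (a lower number here means that less compound is needed, a higher number that more compound is needed for the effect), compound 1 gives 20 nM, the lowest of the two numbers in hand. Compound 2 gives 2240 nM, a higher number that lies beyond the scatter. Compound 3 reaches only a limit of this assay, > 10000 nM. Compound 4, `O=C(O)c1ccccc1-c1ccc(CCc2ncc(C3CCCCC3)[nH]2)cc1`, differs from compound 1 in one place: cyclohexyl in place of 3-cyanobenzyl on an aromatic carbon. Going by the values given here, no measured pair makes this same change, so its size is not yet known; the two compounds that carry a butyl group in this position, compound 2 and compound 3, both give higher numbers than compound 1. Compound 4 is therefore expected to need more compound than compound 1, a step of a 15-fold higher number from compound 1 to compound 4 (1.18 log units; beyond the scatter), with an estimated 300 nM and a range from 50 nM to 3000 nM.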

Compound 4, half-maximal effective concentration: 14.7 nM
Compound 4: the middle estimate sits 20-fold (1.31 log units) above what was measured; the measured number lies below the stated range.
By their numbers in this assay, from the lowest: compounds 4 and 1 (each within the scatter of the next); then compound 2. At a limit, above all of these: compound 3.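

In this assay the exchange of 3-cyanobenzyl for cyclohexyl gives a 1.4-fold lower number from compound 1 to compound 4 (0.13 log units; within the scatter) and so leaves the two compounds level. At this position, then, neither the nitrile nor the aromatic ring of 3-cyanobenzyl is required, as a non-aromatic carbon ring serves equally well. Nothing given here accounts for this.

Going by these compounds, whether a butyl group would do the same on the core of compound 1 remains open. So does the effect of an amine or a hydroxyl group on the cyclohexyl ring.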